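Aryl substituent swap on the shared core

A few compounds are considered here, and "the series" means these few. Any claim that something is new, unique, unknown or untested is made for them only; others in the source may bear on it.

compound 1 `CCC1=C(O)c2c(oc(-c3cccc(C(F)(F)F)c3)cc2=O)C(CC)(CC)C1=O`: 5.42 uM
compound 2 `CCC1=C(O)c2c(oc(-c3cccc(OC)c3)cc2=O)C(CC)(CC)C1=O`: 1.22 uM
compound 3 `CCC1=C(O)c2c(oc(-c3ccc(OC)c(OC)c3)cc2=O)C(CC)(CC)C1=O`: 1 uM

In a functional assay on KBVIN cells (Homo sapiens) for antiproliferative activity, read by sulforhodamine B assay, with a stated time of 3 days (a higher number here means that more compound is needed for the effect, a lower number that less compound is needed), compound 2 gives 1.22 uM. Compound 3 lies within the scatter of it, a 1.2-fold lower number from compound 2 to compound 3 (0.09 log units; within the scatter), whereas compound 1 is set apart by a 4.4-fold lower number from compound 1 to compound 2 (0.65 log units; beyond the scatter). Compound 4 `CCC1=C(O)c2c(oc(-c3cc(C)cc(C)c3)cc2=O)C(CC)(CC)C1=O` differs from compound 2 by 3,5-dimethylphenyl in place of 3-methoxyphenyl on an aromatic carbon. For the measured compounds named here, no measured step covers this exact change. The closest hint is that compound 1, which also lacks a hydrogen-bond acceptor on the aryl group, gives the higher number 5.42 uM. A modest rise is therefore expected, a 2.0-fold higher number from compound 2 to compound 4 (0.31 log units; beyond the scatter), though the evidence is thin. Compound 4 is estimated at 2.5 uM, within a range of 1 uM to 6 uM.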

Compound 4, concentration for half-maximal effect: 0.45 uM
Compound 4: the middle estimate sits 5.6-fold (0.74 log units) above what was measured; measured number outside the range, below it.
By their numbers in this assay, from the lowest: compound 4; then compounds 3 and 2 (each within the scatter of the next); then compound 1.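

In this assay, 3,5-dimethylphenyl in place of 3-methoxyphenyl gives a 2.7-fold lower number from compound 2 to compound 4 (0.43 log units; beyond the scatter). A low number at this position therefore does not depend on the methoxy oxygen, and an aryl group with no hydrogen-bond acceptor can serve here. Nothing on hand accounts for this step.

The compounds shown leave open whether one methyl group, as in 3-methylphenyl, would read like the two in compound 4. Also open, as far as these compounds go, is how a longer chain such as ethyl or an amine such as dimethylamino would read on this aryl group.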